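Swapping the Side Group on Compound 2

The compounds below may be only part of what the source reports. "The series", "measured", "known", "first", "only" and "open" are said of these compounds alone.

Within the data shown here, compound 2 `CCCCCCC(CCO)n1cnc2c(Cl)ncnc21` gives 11900 nM in a functional assay on HCT-116 cells (Homo sapiens) for antiproliferative activity, read by MTT assay, with a stated time of 48 h (a lower number here means a stronger inhibitor, a higher number a weaker inhibitor), the only value so far that is a true number. Most of the other data are bounded by the limit of > 50000 nM in this assay, at which 2 of the 3 values shown sit.

Compound 4 `C=C(CO)C(CCCCCC)n1cnc2c(Cl)ncnc21` keeps the chloro group of compound 2 and changes the side chain: 1-(hydroxymethyl)ethenyl in place of 2-hydroxyethyl on a saturated chain carbon bound to an aromatic nitrogen and a saturated chain carbon. In words, 1-(hydroxymethyl)ethenyl stands in place of 2-hydroxyethyl on a saturated chain carbon bound to an aromatic nitrogen and a saturated chain carbon.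

Among the measured compounds shown here, the one measured step is a change elsewhere. Compound 3 `CCCCCCC(CCO)n1cnc2c(NC)ncnc21` reads > 50000 nM, which is a limit and not a number. Its step, with methylamino in place of chloro on an aromatic carbon, is an at least 4.2-fold higher number from compound 2 to compound 3 (0.62 log units; beyond the scatter). This is beyond the scatter, but it says little about a change on the chain carbon.

Closer evidence comes from compound 1 `C=C(CO)C(CCCCC)n1cnc2c(Cl)ncnc21`, which also carries 1-(hydroxymethyl)ethenyl but does not share the rest of the chain of compound 4. Compound 1 reads > 50000 nM, again a limit.

This single limit points towards weaker inhibition, so the expected step is a 2.1-fold higher number from compound 2 to compound 4 (0.32 log units; beyond the scatter). For compound 4 the estimated value is 25000 nM, with an expected range from 8000 nM to 50000 nM.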

Compound 4, half-maximal inhibitory concentration: 30200 nM
Compound 4: middle estimate off by 1.2-fold (0.08 log units), on the low side, and the stated range covers the measured number.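

The swap on this chain carbon now has a true number on both sides: in this assay, putting 1-(hydroxymethyl)ethenyl in place of 2-hydroxyethyl gives a 2.5-fold higher number from compound 2 to compound 4 (0.40 log units; beyond the scatter). Among these compounds, until now the only measured step was the change of chloro to methylamino on the aromatic carbon, so this is the first direct reading of a change on the chain, and it shows a modest loss of activity with the chloro group kept. The second step, methyl in place of hydrogen at the end of the chain, gives an at least 1.6-fold lower number from compound 1 to compound 4 (0.21 log units; that floor lies within the scatter), so it does not establish any effect of that extra carbon, and this comparison stays open-ended because the reading of compound 1 is a limit and not a number: the limit of > 50000 nM in this assay, at which 2 of the 4 values shown sit.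

As far as these compounds go, only one replacement for 2-hydroxyethyl on this chain carbon appears here, so it remains open how an amine or a carboxylic acid would read in that place. Also open, from the compounds shown here alone, is whether a longer chain would move the number, and how methylamino on the aromatic carbon would read together with 1-(hydroxymethyl)ethenyl.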